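The source may report more compounds than this note shows. Statements on the series, on what has been measured and on what is new or still open speak of the compounds shown alone.

Measured so far in a functional assay on A549 cells (Homo sapiens), read by sulforhodamine B assay, with a stated time of 5 days; on this read-out lower numbers stand for stronger inhibition of growth and higher numbers for weaker inhibition of growth:
compound 1 `OC[C@H]1O[C@@H](n2cc(F)c3c(-c4ccccc4)ncnc32)[C@H](O)[C@@H]1O`, a limit of the assay only, > 10000 nM.
compound 2 `OC[C@H]1O[C@@H](n2cc(F)c3c(-c4nccs4)ncnc32)[C@H](O)[C@@H]1O`, 900 nM.
compound 3 `OC[C@H]1O[C@@H](n2cc(F)c3c(-c4c[nH]cn4)ncnc32)[C@H](O)[C@@H]1O`, a limit of the assay only, > 10000 nM.

Compound 1 therefore stands at the limit (the limit of > 10000 nM in this assay, at which 2 of the 3 values shown sit), the same limit at which compound 3 sits. Not yet measured is compound 4 `OC[C@H]1O[C@@H](n2cc(F)c3c(-c4ccoc4)ncnc32)[C@H](O)[C@@H]1O`, which differs from compound 1 by furan-3-yl in place of phenyl on an aromatic carbon. Among the compounds with values here, the steps that bear on this change are an at least 11-fold lower number from compound 1 to compound 2 (1.04 log units; beyond the scatter) and a step that the two limits leave unreadable from compound 1 to compound 3; between those two rings lies an at least 11-fold higher number from compound 2 to compound 3 (1.04 log units; beyond the scatter). A five-membered heteroaromatic ring in place of phenyl thus gave either a large drop, as with compound 2, or nothing readable, as with compound 3. For compound 4 an intermediate step is expected, an at least 1.6-fold lower number from compound 1 to compound 4 (0.22 log units; that floor lies within the scatter), and the estimate in this assay is 6000 nM, with a range from 1500 nM to 20000 nM.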

Compound 4, concentration for 50% growth inhibition: 60 nM
The estimate for compound 4 lay 100-fold (2.00 log units) above the measured number; measured number outside the range, below it.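

Furan-3-yl in place of phenyl gives an at least 160-fold lower number from compound 1 to compound 4 (2.22 log units; beyond the scatter) in this assay, and in place of 1H-imidazol-4-yl it gives an at least 160-fold lower number from compound 3 to compound 4 (2.22 log units; beyond the scatter). It also goes clearly past the best earlier ring, with a 15-fold lower number from compound 2 to compound 4 (1.18 log units; beyond the scatter), so a five-membered ring at this position can do much more than compound 2 showed, though compound 3 goes against any rule based on ring size alone. The first two steps are floors only: the limit of > 10000 nM in this assay, at which 2 of the 4 values shown sit.

Going by these compounds, what the ring oxygen contributes stays open. Furan-2-yl and thiophen-3-yl would separate the hetero atom from its point of attachment.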